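This account rests on a few compounds, and the source may have more. Where it says the series, first, only, none or still open, it means among the compounds named here.

Working notes on the ester series.

Compound 1 `CCCCc1nc(C)c(CC(=O)OC(C)C)c(=O)n1Cc1ccc(-c2ccccc2-c2noc(=O)[nH]2)cc1` gives 17.5% in an ADME assay on microsomes from liver (Homo sapiens) for metabolic stability, with a stated time of 30 min; on this read-out lower numbers stand for a less stable compound and higher numbers for a more stable compound. Compound 2 `CCCCc1nc(C)c(CC(=O)OCC(C)C)c(=O)n1Cc1ccc(-c2ccccc2-c2noc(=O)[nH]2)cc1` gives 2.4% in this assay, and compound 3 `CCCCc1nc(C)c(CC(=O)OC2CCCCC2)c(=O)n1Cc1ccc(-c2ccccc2-c2noc(=O)[nH]2)cc1` gives 3.9% in this assay. The steps between them are a number 15.1 percentage points lower from compound 1 to compound 2 (beyond the scatter), a number 13.6 percentage points lower from compound 1 to compound 3 (beyond the scatter) and a number 1.5 percentage points higher from compound 2 to compound 3 (within the scatter). On these three numbers compound 3 stands second highest: its gap to compound 2 is within the scatter, its gap to compound 1 is beyond it.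

Compound 4 `CC#CCOC(=O)Cc1c(C)nc(CCCC)n(Cc2ccc(-c3ccccc3-c3noc(=O)[nH]3)cc2)c1=O` is not yet measured in this assay. The change from compound 3 is but-2-yn-1-yl in place of cyclohexyl on an oxygen next to a carbonyl group. Every measured step in this set alters the group on the same oxygen, so all three bear on it; the two that moved beyond the scatter, a number 15.1 percentage points lower from compound 1 to compound 2 (beyond the scatter) and a number 13.6 percentage points lower from compound 1 to compound 3 (beyond the scatter), both ran downward, while a number 1.5 percentage points higher from compound 2 to compound 3 (within the scatter) stayed within it. Nothing measured shows a group of this kind on that oxygen, so the expectation leans on the low level shared by compound 2 and compound 3. Compound 4 is therefore expected to give about 6% in this assay, with a range from 1% to 20%. That estimate means a step of a number 2.1 percentage points higher from compound 3 to compound 4 (within the scatter), expected to stay within the scatter.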

Compound 4, percent of the compound remaining: 32%
Compound 4: the middle estimate sits 26 percentage points below what was measured, and the stated range ends below it.
By their numbers in this assay, from the lowest: compounds 2 and 3 (each within the scatter of the next); then compound 1; then compound 4.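

In this assay, within the data shown here, the group on an oxygen next to a carbonyl group can also raise the number: but-2-yn-1-yl gives a number 28.1 percentage points higher from compound 3 to compound 4 (beyond the scatter) and a number 29.6 percentage points higher from compound 2 to compound 4 (beyond the scatter), whereas the earlier steps beyond the scatter both ran downward. The isopropyl ester is exceeded too, with a number 14.5 percentage points higher from compound 1 to compound 4 (beyond the scatter), so compound 4, with no ring and a triple bond outside aromatic rings, stands highest of the four, and the range at this position is wider than the earlier esters showed. Nothing at hand accounts for this rise.

As far as these compounds go, whether the step belongs to the triple bond or to the unbranched chain stays open, and a butyl or but-2-en-1-yl group on this oxygen would separate the two. Also open, from the compounds shown here alone, is how a longer chain ending in a triple bond would read in this assay on the same oxygen.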